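The compounds below may be only part of what the source reports. "The series", "measured", "known", "first", "only" and "open" are said of these compounds alone.

Measured so far in a functional assay on QGY-7703 cells (Homo sapiens) for cytotoxicity, read by MTT assay, with a stated time of 24 h; a higher number here means a weaker inhibitor, a lower number a stronger inhibitor:
- compound 1 `Cc1ccc(S(=O)(=O)N2C/C(=C\c3ccncc3)C(=O)/C(=C/c3ccccc3F)C2)cc1`: > 20000 nM (a limit of the assay, not a number)
- compound 2 `Cc1ccc(S(=O)(=O)N2C/C(=C\c3cccnc3)C(=O)/C(=C/c3ccccc3C(F)(F)F)C2)cc1`: 6170 nM
- compound 3 `Cc1ccc(S(=O)(=O)N2C/C(=C\c3ccncc3)C(=O)/C(=C/c3ccccc3C(F)(F)F)C2)cc1`: 5090 nM

Within the data shown here, compound 3 shares the low end of the numbers in this assay with the only other compound that has a numeric value. Pyridin-4-yl in place of pyridin-3-yl gave a 1.2-fold lower number from compound 2 to compound 3 (0.08 log units; within the scatter). Trifluoromethyl in place of fluoro gave an at least 3.9-fold lower number from compound 1 to compound 3 (0.59 log units; beyond the scatter).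

Next is compound 4 `N#Cc1ccc(S(=O)(=O)N2C/C(=C\c3ccncc3)C(=O)/C(=C/c3ccccc3C(F)(F)F)C2)cc1`, with the change cyano in place of methyl on an aromatic carbon, 4-methylphenyl to 4-cyanophenyl. Among the measured compounds shown here, no measured step touches this place, so both steps bear on it only indirectly. They show one change that stayed within the scatter and one that went beyond it, on other parts of the molecule. The series therefore gives no direction for this change, and the expectation stays close to compound 3 at 5090 nM, with a wide margin. The expected outcome is a 1.1-fold lower number from compound 3 to compound 4 (0.05 log units; within the scatter), with no clear shift beyond the scatter. For compound 4 the estimated value is 4500 nM, with an expected range of 1800 nM to 12000 nM.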

Compound 4, half-maximal inhibitory concentration: 6290 nM
The estimate for compound 4 lay 1.4-fold (0.15 log units) below the measured number; measured number inside the range.
By their numbers in this assay, from the lowest: compounds 3, 2 and 4 (each within the scatter of the next). At a limit, above all of these: compound 1.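

Cyano in place of methyl, read in this assay, gave a 1.2-fold higher number from compound 3 to compound 4 (0.09 log units; within the scatter), so the change from 4-methylphenyl to 4-cyanophenyl produces no shift that can be told from the scatter. Among these compounds, this is the first reading at this position, and it shows that the sulfonyl aryl group accepts an added nitrile here without a clear change in the number. Among the changes shown, only trifluoromethyl in place of fluoro goes beyond the scatter, and nothing measured on these compounds offers a cause for the flat result at this position.

Going by these compounds, whether an amine or a carboxylic acid at this place would move the number beyond the scatter stays open. Also open, on these data alone, is whether cyano would read the same with fluoro in place of trifluoromethyl, or with pyridin-3-yl in place of pyridin-4-yl.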